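Trimethoxyphenyl chalcone analogue of a pyrazolopyrimidine series

This account rests on a few compounds, and the source may have more. Where it says the series, first, only, none or still open, it means among the compounds named here.

Measured so far:
compound 1 `COc1ccc(-c2cc(C(=O)/C=C/c3ccc(Cl)cc3)nc3cc(-c4ccccc4)nn23)cc1OC` — 22000 nM
compound 2 `COc1ccc(-c2cc(C(=O)/C=C/c3ccc(C)cc3)nc3cc(-c4ccccc4)nn23)cc1OC` — 22200 nM

In a functional assay on A549 cells (Homo sapiens) for antiproliferative activity, read by MTT assay, with a stated time of 24 h (a lower number here means a stronger inhibitor, a higher number a weaker inhibitor), compound 1 gives 22000 nM. Compound 2 `COc1ccc(-c2cc(C(=O)/C=C/c3ccc(C)cc3)nc3cc(-c4ccccc4)nn23)cc1OC` differs from compound 1 by a methyl in place of a chloro on an aromatic carbon, and in this assay compound 2 gives 22200 nM; the step of a 1.0-fold higher number from compound 1 to compound 2 (0.00 log units; within the scatter), so the two compounds cannot be told apart. Compound 2 thus stands at the higher of the two numbers, with compound 1 within the scatter of it.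

Compound 3 `COc1ccc(-c2cc(C(=O)/C=C/c3cc(OC)c(OC)c(OC)c3)nc3cc(-c4ccccc4)nn23)cc1OC` carries the change (3,4,5-trimethoxyphenyl in place of 4-methylphenyl on a double-bonded chain carbon bound to a double-bonded chain carbon). Among the measured compounds shown here, the only measured step, a 1.0-fold higher number from compound 1 to compound 2 (0.00 log units; within the scatter), exchanges one small substituent on that aromatic ring for another and does not involve a trimethoxyphenyl group, so it bears on this change only weakly. With nothing that shows a move beyond the scatter, compound 3 is expected to give a number close to compound 2, and its estimated step is a 1.5-fold lower number from compound 2 to compound 3 (0.17 log units; within the scatter). The estimate for compound 3 is 15000 nM, with a range from 5000 nM to 40000 nM.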

Compound 3, half-maximal inhibitory concentration: 15400 nM
The estimate for compound 3 lay 1.0-fold (0.01 log units) below the measured number; the measured number falls inside the stated range.
By their numbers in this assay, from the lowest: compounds 3, 1 and 2 (each within the scatter of the next).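

In this assay, 3,4,5-trimethoxyphenyl in place of 4-methylphenyl on a double-bonded chain carbon bound to a double-bonded chain carbon gives a 1.4-fold lower number from compound 2 to compound 3 (0.16 log units; within the scatter), and the same group in place of 4-chlorophenyl gives a 1.4-fold lower number from compound 1 to compound 3 (0.15 log units; within the scatter). The earlier step had only exchanged one substituent on the aromatic ring for another, whereas this change raises the group from 7 to 12 heavy atoms and from 0 to 3 hydrogen-bond acceptors, yet all three compounds remain within the scatter of one another, so this position has so far tolerated a larger change without a number that can be told apart. Nothing measured alongside these numbers bears on this result.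

The compounds shown leave open whether an amine or a carboxylic acid on the aromatic ring at this position, or a longer chain in place of the double-bonded chain, would move the number beyond the scatter. They also leave open whether changes elsewhere on the shared core would have a larger effect than any change seen here.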